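From Methyl to Bromo on a Phenyl Ring

The compounds below may be only part of what the source reports. "The series", "measured", "known", "first", "only" and "open" are said of these compounds alone.

Measured in a functional assay on HCT-116 cells (Homo sapiens) for antiproliferative activity, read by MTT assay, with a stated time of 72 h; a lower number here means a stronger inhibitor, a higher number a weaker inhibitor
Compound 1 (`COc1ccc(NC(=S)Nc2nc(C(=O)NCCCc3ccccc3)cs2)cc1`) gives 44800 nM
Compound 2 (`Cc1ccc(-c2c(CN3CCCCC3)nc3scc(C(=O)O)n23)cc1`) gives 13800 nM

Compound 2 holds the lower of these two numbers, and its gap to compound 1 lies beyond the scatter. Compound 3 (`O=C(O)c1csc2nc(CN3CCCCC3)c(-c3ccc(Br)cc3)n12`) differs from compound 2 in one place (bromo in place of methyl on an aromatic carbon): bromo in place of methyl on an aromatic carbon. Among the measured compounds shown here, no measured pair shows this swap. With compound 2 at 13800 nM as the only anchor, no step beyond the scatter is expected in this assay and no clear direction. The expected move is a 1.2-fold lower number from compound 2 to compound 3 (0.06 log units; within the scatter) (an estimate). Compound 3 is estimated at 12000 nM (range 5000 nM to 30000 nM).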

Compound 3, half-maximal inhibitory concentration: > 100000 nM
Compound 3: no number, only a limit; the forecaster's own chance of this, stated with the estimate: 10%; middle value at least 8.3-fold (0.92 log units) from the limit.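

On the phenyl ring, going from 4-methylphenyl to 4-bromophenyl matters in this assay: the swap gives an at least 7.2-fold higher number from compound 2 to compound 3 (0.86 log units; beyond the scatter). This shows that the place para to a large group responds to an exchange of one heavy atom, which the two earlier compounds, differing in many places, could not show. Compound 3 stands at > 100000 nM, which is a limit of the assay and not a number: the limit of > 100000 nM in this assay, at which 1 of the 3 values shown sits.

As far as these compounds go, whether fluoro, chloro or an amine at this place would read like methyl or like bromo stays open. So does what a plain hydrogen there would give.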